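Diaminoquinoxaline series: aryl ether to aryl thioether swap

A few compounds are considered here, and "the series" means these few. Any claim that something is new, unique, unknown or untested is made for them only; others in the source may bear on it.

Measured compounds:
compound 1, `Nc1cc(N)c2nc(-c3ccccc3)c(Oc3ccc(F)cc3)nc2c1`, < 100000 nM
compound 2, `COc1cc(CNc2nc3cc(N)cc(N)c3nc2-c2ccccc2)cc(OC)c1OC`, 31600 nM
compound 3, `COc1ccc(CNc2nc3cc(N)cc(N)c3nc2-c2ccccc2)cc1`, 64600 nM

The read-out throughout is a functional assay on MDA-MB-231 cells (Homo sapiens) for inhibition, read by sulforhodamine B assay, with a stated time of 48 h; on this read-out lower numbers stand for higher toxicity in this test and higher numbers for lower toxicity in this test. For compound 1 the value < 100000 nM is a limit of the assay and not a number. Compound 2 gives 31600 nM and compound 3 gives 64600 nM; the two carry benzylamino groups with different methoxy patterns on the same core, and their values sit within the usual scatter of each other, so nothing can be read from their order.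

The unmeasured compound 4, `COc1ccc(Sc2nc3cc(N)cc(N)c3nc2-c2ccccc2)cc1`, differs from compound 1 by a single change: (4-methoxyphenyl)sulfanyl in place of 4-fluorophenoxy on an aromatic carbon. The change keeps the aryl group on the core but trades the ether link for a thioether and the fluoro for a methoxy.

Among the compounds with values here, no measured pair in the set shares a single change, so no measured step guides the size of this one. Because compound 1 sits at the limit (the limit of < 100000 nM in this assay, at which 1 of the 3 values shown sits), the direction cannot be fixed from the numbers; the best anchor is the range spanned by compound 2 and compound 3. The step from compound 1 to compound 4 is therefore expected to be a step that the limit leaves unreadable from compound 1 to compound 4, roughly none beyond the scatter relative to a value near the limit. Compound 4 is estimated at 45000 nM, with a range from 15000 nM to 100000 nM.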

Compound 4, concentration lethal to 50% of the cells: < 100000 nM
Compound 4: a limit, no number; the forecaster's own chance of this, stated with the estimate: 30%; the middle value is on the limit's open side.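

In this assay compound 4 gives < 100000 nM as a limit of the assay and not a number. Compound 1 also stands at a limit, so no step can be read between compound 1 and compound 4: the limit of < 100000 nM in this assay, at which 2 of the 4 values shown sit.

The compounds shown leave open whether (4-methoxyphenyl)sulfanyl in place of 4-fluorophenoxy shifts the value in this assay at all, and in which direction.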